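Compound 1 to compound 4: solubility seen only through limits

This account rests on a few compounds, and the source may have more. Where it says the series, first, only, none or still open, it means among the compounds named here.

In a physicochemical assay for solubility (on this read-out lower numbers stand for lower solubility and higher numbers for higher solubility), compound 1, `O=C(O)c1ccc(C(=O)/C(=C\c2ccc(F)c([N+](=O)[O-])c2)S(=O)(=O)Cc2ccc(Br)cc2)cc1`, gives < 1000 ug/mL, which is a limit of the assay and not a number. Compound 2, `O=C(O)c1ccc(C(=O)/C(=C\c2ccc(Br)c([N+](=O)[O-])c2)SCc2ccc(Br)cc2)cc1`, gives < 1000 ug/mL, also a limit. Compound 3, `O=C(O)c1ccc(C(=O)/C(=C\c2ccc(Cl)c([N+](=O)[O-])c2)S(=O)(=O)Cc2ccc(Br)cc2)cc1`, gives < 1000 ug/mL, a limit as well. The evidence so far therefore comes down to the limit of < 1000 ug/mL in this assay, at which 3 of the 3 values shown sit, so none of the three can be ranked against the others.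

Compound 4, `O=C(O)c1ccc(C(=O)/C(=C\c2ccc(F)c([N+](=O)[O-])c2)[S+]([O-])Cc2ccc(Br)cc2)cc1`, has not yet been measured. It keeps the core of compound 1 and changes in one place, where the (4-bromobenzyl)sulfonyl group leaves: a group of 10 heavy atoms (7 carbon, 1 oxygen, 1 sulfur, 1 bromine; one six-membered aromatic ring of carbon only) in place of a group of 11 heavy atoms (7 carbon, 2 oxygen, 1 sulfur, 1 bromine; one six-membered aromatic ring of carbon only), on a double-bonded chain carbon bound to a carbonyl carbon and a double-bonded chain carbon.

For the measured compounds named here, only one measured step offers any guide, and it is a different change at a different place: chloro in place of fluoro on an aromatic carbon. That is a step that the two limits leave unreadable from compound 1 to compound 3, so it gives no size to carry over. With no readable step and no readable direction, nothing beyond the usual scatter can be expected in this assay. The expected change is a step that the limit leaves unreadable from compound 1 to compound 4, and this estimate has no firm direction. Compound 4 is estimated at about 500 ug/mL, with an expected range of 100 ug/mL to 1000 ug/mL. A limit rather than a number remains the most likely report for compound 4.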

Compound 4, solubility: < 1000 ug/mL
Compound 4: only a limit was reported; the forecaster's own chance of this, stated with the estimate: 85%; the middle value is on the limit's open side.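

In this assay compound 4 gives < 1000 ug/mL, which is a limit of the assay and not a number, so its step from compound 1 cannot be read, any more than the step from compound 1 to compound 3. How compound 1, compound 2, compound 3 and compound 4 actually rank in solubility stays open, because everything shown comes down to a single limit: the limit of < 1000 ug/mL in this assay, at which 4 of the 4 values shown sit.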